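Swapping the five-membered ring on the piperidine carbon

The source may hold more compounds than are shown below. What is called first, only, known or untested is meant among the compounds shown, and "the series" means these compounds.

In an ADME assay on microsomes from liver (Homo sapiens) for metabolic stability, with a stated time of 30 min (a higher number here means that more of the compound is left, a lower number that less of the compound is left), compound 2 `Cc1nc(N2CCC(N3CCCS3(=O)=O)CC2)nc2ccc(NC(=O)/C=C/c3ccc(OC(F)(F)F)cc3)cc12` gives 85%, the only number shown; compound 1 `Cc1nc(N2CCC(O)(C3CCC3)CC2)nc2ccc(NC(=O)/C=C/c3ccc(Cl)cc3)cc12` is "not determined" (no result reported) in this assay. Compound 3 `Cc1nc(N2CCC(N3CCN(C)C3=O)CC2)nc2ccc(NC(=O)/C=C/c3ccc(OC(F)(F)F)cc3)cc12` differs from compound 2 by a group of 7 heavy atoms (4 carbon, 2 nitrogen, 1 oxygen; one five-membered non-aromatic ring with 2 hetero atoms) in place of a group of 7 heavy atoms (3 carbon, 1 nitrogen, 2 oxygen, 1 sulfur; one five-membered non-aromatic ring with 2 hetero atoms), on a saturated ring carbon. No step between measured compounds is shown, so nothing indicates how far this change moves the read-out in this assay. Compound 3 is therefore expected to stay near compound 2, with a step of a number 5 percentage points lower from compound 2 to compound 3 (within the scatter) that is expected to lie within the scatter. The estimate for compound 3 in this assay is 80%, ranging from 60% to 95%.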

Compound 3, percent of the compound remaining: 33%
Compound 3: the middle estimate sits 47 percentage points above what was measured; measured number outside the range, below it.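

In this assay putting 3-methyl-2-oxoimidazolidin-1-yl on this saturated ring carbon in place of the earlier five-membered ring gives a number 52 percentage points lower from compound 2 to compound 3 (beyond the scatter) while the ring size and the count of 7 heavy atoms stay the same. This position is therefore not indifferent to which ring it carries, and the read-out here depends on more than the size of the group. Nothing measured bears on the reason for this step. The compounds shown leave open whether the methyl group on the ring nitrogen contributes to the step, and how a morpholine or an open-chain amine on the same carbon would read.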